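From isopropylcarbonyl to (tert-butyl)carbonyl

This account rests on a few compounds, and the source may have more. Where it says the series, first, only, none or still open, it means among the compounds named here.

compound 1 (`CCC(=O)N1C[C@H](NC(=O)c2ccc(-n3ccccc3=O)cc2)[C@H](NC(=O)c2ccc(Cl)s2)C1`) gives > 100000 nM as a limit
compound 2 (`CC(C)C(=O)N1C[C@H](NC(=O)c2ccc(-n3ccccc3=O)cc2)[C@H](NC(=O)c2ccc(Cl)s2)C1`) gives > 100000 nM as a limit

In an ADME assay on HEK293 cells (Homo sapiens) for cytotoxicity (a lower number here means a stronger inhibitor, a higher number a weaker inhibitor), compound 2 gives > 100000 nM as a limit of the assay, not a number. Within the data shown here, the series so far reads the limit of > 100000 nM in this assay, at which 2 of the 2 values shown sit, and nothing more. Compound 3 (`CC(C)(C)C(=O)N1C[C@H](NC(=O)c2ccc(-n3ccccc3=O)cc2)[C@H](NC(=O)c2ccc(Cl)s2)C1`) carries methyl in place of hydrogen on a saturated chain carbon bound to a carbonyl carbon and two saturated chain carbons. Among the measured compounds shown here, the one measured step of this kind (a step that the two limits leave unreadable from compound 1 to compound 2) has no readable size and gives no direction. No step beyond the scatter is expected in this assay (a number no higher from compound 2 to compound 3 (the limit leaves the size open)) for this change. Compound 3 is expected at 100000 nM (range 50000 nM to 200000 nM) and most likely reported as a limit again.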

Compound 3, half-maximal inhibitory concentration: > 100000 nM
Compound 3 ended at the assay's limit (the forecaster's own chance of this, stated with the estimate: 90%); the middle value sits exactly at the limit.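

In this assay compound 3 gives > 100000 nM, a limit and not a number. Compound 1 and compound 2 also sit at limits, so no step among these compounds can be read. On these data alone, whether isopropylcarbonyl to (tert-butyl)carbonyl shifts the read-out at all stays open.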